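A few compounds are considered here, and "the series" means these few. Any claim that something is new, unique, unknown or untested is made for them only; others in the source may bear on it.

Measured so far in a functional assay for inhibition, with a stated time of 5 min, tested at 1 mM; a higher number here means more inhibition at the concentration tested (going by the name of the read-out), a lower number less inhibition: compound 1 `COc1cc(/C(Cl)=C/C=C(\C#N)C(=O)c2c[nH]c3ccccc23)cc(OC)c1OC` gives 59.1%; compound 2 `COc1ccc2[nH]cc(C(=O)/C(C#N)=C/C=C(\Cl)c3ccc(OC)c(OC)c3)c2c1` gives 58.2%; compound 3 `COc1cc(/C(Cl)=C/C=C(\C#N)C(=O)c2c[nH]c3ccc(Br)cc23)cc(OC)c1OC` gives 50%.

Compound 3 has the lowest of the three numbers, yet its gaps to compound 2 and to compound 1 both fall within the scatter, so none of the three can be set apart from the others. Compound 4 `COc1ccc2[nH]cc(C(=O)/C(C#N)=C/C=C(\Cl)c3cc(OC)c(OC)c(OC)c3)c2c1` differs from compound 3 by methoxy in place of bromo on an aromatic carbon. For the measured compounds named here, the one measured step at this place, a number 9.1 percentage points lower from compound 1 to compound 3 (within the scatter), stayed within the scatter, and compound 2, which carries a methoxy on its core, shows a number close to that of compound 1. A change at this carbon is therefore expected to move the read-out little, and the expected step of a number 6 percentage points higher from compound 3 to compound 4 (within the scatter) should stay within the scatter. Compound 4 is estimated at 56%, between 45% and 67%.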

Compound 4, a percentage reported as inhibition, at one concentration (the size of the read-out at that concentration, not a potency): 50%
Estimate against measurement, compound 4: 6 percentage points above, and the stated range covers the measured number.
By their numbers in this assay, from the lowest: compounds 3, 4, 2 and 1 (each within the scatter of the next).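

Bromo and methoxy on this aromatic carbon, part of a fused system of two rings, cannot be told apart, with no change at the digits printed from compound 3 to compound 4 (within the scatter). A methoxy that replaces hydrogen on this same carbon gives no separable result either, with a number 9.1 percentage points lower from compound 1 to compound 4 (within the scatter), and neither does a methoxy that replaces hydrogen at a different aromatic carbon, with a number 8.2 percentage points lower from compound 2 to compound 4 (within the scatter). No measured evidence offers an explanation for these results. Going by these compounds, whether an amine or a carboxylic acid on this carbon would move the read-out beyond the scatter stays open.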